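A few compounds are considered here, and "the series" means these few. Any claim that something is new, unique, unknown or untested is made for them only; others in the source may bear on it.

Compound 1 `O=C(Nc1cccc(CNc2nccnc2Cl)c1)Nc1ccccc1F` and compound 2 `Cc1ccccc1NC(=O)Nc1cccc(CNc2nccnc2Cl)c1` share one core and differ in a single group on an aromatic carbon, methyl in place of fluoro. In a functional assay on HepG2 cells (Homo sapiens) for antiproliferative activity, read by MTT assay, with a stated time of 48 h (a higher number here means a weaker inhibitor, a lower number a stronger inhibitor), compound 1 gives 10500 nM, and compound 2 gives 15300 nM. For the measured compounds named here, the step of a 1.5-fold higher number from compound 1 to compound 2 (0.16 log units; within the scatter) falls within the scatter, so the two numbers cannot be told apart, and compound 2 stands alongside compound 1 with no measured compound set apart from it beyond the scatter. Compound 3 `O=C(Nc1cccc(CNc2nccnc2Cl)c1)Nc1ccc(F)c(Cl)c1` carries the change (3-chloro-4-fluorophenyl in place of 2-methylphenyl on an amide-type nitrogen). Going by the values given here, the only measured step that touches this same ring, a 1.5-fold higher number from compound 1 to compound 2 (0.16 log units; within the scatter), moved nothing beyond the scatter, and no other measured pair speaks to the new pattern of substituents. On that basis the step of a 1.3-fold lower number from compound 2 to compound 3 (0.11 log units; within the scatter) is expected to stay small. Compound 3 is therefore estimated at 12000 nM, with a range from 4500 nM to 32000 nM.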

Compound 3, half-maximal inhibitory concentration: 6750 nM
Beside the measured number, compound 3's estimate is 1.8-fold (0.25 log units) above it; the measured number falls inside the stated range.
By their numbers in this assay, from the lowest: compounds 3, 1 and 2 (each within the scatter of the next, the first and the last beyond it).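

In this assay, this position now shows a step beyond the scatter: 3-chloro-4-fluorophenyl in place of 2-methylphenyl gives a 2.3-fold lower number from compound 2 to compound 3 (0.36 log units; beyond the scatter) and so registers, though only modestly. Against 2-fluorophenyl the same group gives a 1.6-fold lower number from compound 1 to compound 3 (0.19 log units; within the scatter) and stays within the scatter, so compound 3 cannot be told apart from compound 1, and the separation holds only against compound 2. No measurement here accounts for this difference between the rings.

Chlorine and fluorine enter together in compound 3, so what each contributes alone remains unknown. Also open, as far as these compounds go, is whether an amine or a carboxylic acid on this phenyl ring, or a longer chain in its place, would move the number further than these small groups do.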